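From Propyl to Benzyl on a Sulfonyl Sulfur

The source may hold more compounds than are shown below. What is called first, only, known or untested is meant among the compounds shown, and "the series" means these compounds.

Measured compounds in a functional assay on Huh-7 cells (Homo sapiens) for cytotoxicity, read by MTT assay, with a stated time of 72 h; a higher number here means that more compound is tolerated, a lower number that less compound is tolerated:
Compound 1 `C1CCCC2(CC1)OOC1(CCCCCC1)OO2`: > 100 ug/mL
Compound 2 `CS(=O)(=O)N1CCC2(CC1)OOC1(CCCCCC1)OO2`: > 100 ug/mL
Compound 3 `CCCS(=O)(=O)N1CCC2(CC1)OOC1(CCCC1)OO2`: > 100 ug/mL

None of these three entries is an exact number. The whole measured set comes down to the limit of > 100 ug/mL in this assay, at which 3 of the 3 values shown sit. Compound 3 therefore stands level with the other two compounds, and its entry of > 100 ug/mL is a limit of the assay. Going by the values given here, how much more compound the cells would tolerate is not known, so the data give no ranking among the three and no measured step to serve as a guide.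

Compound 4 `O=S(=O)(Cc1ccccc1)N1CCC2(CC1)OOC1(CCCC1)OO2` has not yet been measured. It differs from compound 3 by phenyl in place of ethyl on a saturated chain carbon bound to a sulfonyl sulfur. In short, the propyl of compound 3 becomes the benzyl of compound 4.

In this assay, no step beyond the scatter is expected, and the most likely outcome is another limit rather than a number. The expected size of the change, a number no higher from compound 3 to compound 4 (the limit leaves the size open), is an estimate that carries real uncertainty, since the measured compounds offer only limits. For compound 4 the estimated value is 100 ug/mL, with an expected range from 50 ug/mL to 200 ug/mL.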

Compound 4, half-maximal cytotoxic concentration: > 100 ug/mL
Compound 4 ended at the assay's limit (the forecaster's own chance of this, stated with the estimate: 70%); the middle value lies on the limit itself.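

Compound 4 gives [ > 100 ug/mL ], which is a limit of the assay. Compound 3 also stands at a limit, so no step can be read between compound 3 and compound 4 because the set ends at one ceiling: the limit of > 100 ug/mL in this assay, at which 4 of the 4 values shown sit. The compounds shown leave open at what concentration any of them becomes cytotoxic, and whether propyl and benzyl differ at all.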